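Swapping a Saturated Ring for an Aminophenyl Arm

The compounds below may be only part of what the source reports. "The series", "measured", "known", "first", "only" and "open" are said of these compounds alone.

Measured so far:
compound 1 `FC(F)(F)c1cc(NC[C@H]2CCCN2)c2cn[nH]c2c1` — 6090 nM
compound 2 `O=[N+]([O-])c1cc(Cl)ccc1CNc1cc(C(F)(F)F)cc2[nH]ncc12` — 1700 nM

Both compounds were tested in an assay for inhibition of Tryptophan 2,3-dioxygenase (Homo sapiens), with stated times of 10 min and 60 min; on this read-out lower numbers stand for stronger inhibition and higher numbers for weaker inhibition. Compound 1 gives 6090 nM, the higher of the two numbers, so it is the weaker inhibitor of the pair. Compound 2 gives 1700 nM, and the gap between the two lies beyond the usual scatter of repeated measurements.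

Compound 3 `Nc1cccc(CNc2cc(C(F)(F)F)cc3[nH]ncc23)c1` has not yet been measured. It differs from compound 1 in a single place: 3-aminophenyl in place of pyrrolidin-2-yl on a saturated chain carbon bound to a nitrogen on an aromatic ring. Compound 2 also carries an aromatic ring on the saturated chain carbon bound to a nitrogen on an aromatic ring, and because compound 2 gives 1700 nM a move toward a lower number seems plausible for compound 3 as well. The expected step is therefore a 2.0-fold lower number from compound 1 to compound 3 (0.31 log units; beyond the scatter), toward stronger inhibition but modest. For compound 3 the estimate in this assay is 3000 nM, within a range from 800 nM to 10000 nM.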

Compound 3, half-maximal inhibitory concentration: 2510 nM
Compound 3: middle estimate off by 1.2-fold (0.08 log units), on the high side; low and high end bracket the measured number.
By their numbers in this assay, from the lowest: compounds 2 and 3 (each within the scatter of the next); then compound 1.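

In this assay, the position on a saturated chain carbon bound to a nitrogen on an aromatic ring accepts an aromatic ring in place of a saturated one: 3-aminophenyl in place of pyrrolidin-2-yl gives a 2.4-fold lower number from compound 1 to compound 3 (0.38 log units; beyond the scatter). The two groups have the same counts of hydrogen-bond donors and acceptors and no net charge, so the swap changes the ring and removes the defined stereocentre while leaving those counts as they were. Nothing available here explains why the number falls.

From the compounds shown here alone, it remains open whether the amine on the new ring contributes at all, which a plain phenyl ring or a carboxylic acid in place of that amine would test. Going by these compounds, it is also open whether a longer chain between the ring and the nitrogen would be accepted at this position.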